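A few compounds are considered here, and "the series" means these few. Any claim that something is new, unique, unknown or untested is made for them only; others in the source may bear on it.

Measured compounds:
- compound 1, `CC(C)(O)C(=O)N[C@@H](CO)C(=O)O`: in an ADME assay on microsomes from liver (Mus musculus) for metabolic stability, with a stated time of 30 min (a higher number here means that more of the compound is left, a lower number that less of the compound is left), compound 1 has "not determined" (no result reported)
- compound 2, `C=C(C)C(=O)N[C@@H](CO)C(=O)O`: in this assay compound 2 gives 68%
- compound 3, `O=C(CCO)N[C@@H](CO)C(=O)O`: in this assay compound 3 gives 87%

Compound 1 therefore stands nowhere on the numbers: no value for it in this assay has been reported, and the account of the step to compound 4 must rest on the other two compounds alone. Compound 4, `CC(C)C(=O)N[C@@H](CO)C(=O)O`, differs from compound 1 in one place: hydrogen in place of hydroxy on a saturated chain carbon bound to a carbonyl carbon and two saturated chain carbons.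

Among the compounds with values here, only one measured step is known, a number 19 percentage points higher from compound 2 to compound 3 (beyond the scatter), and it concerns the group on the carbonyl carbon rather than the saturated chain carbon where compound 4 differs from compound 1. It shows that the analog bearing a hydroxy group in its side chain, compound 3, retained more than compound 2, which bears none. Compound 4 loses a hydroxy, so, if anything, a step in the opposite direction, toward less remaining, would be expected in this assay, though it may well stay within the scatter. On this basis compound 4 is estimated to give about 72%, within a range of 52% to 90%.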

Compound 4, percent of the compound remaining: 49%
The estimate for compound 4 lay 23 percentage points above the measured number; the whole stated range lies above it.
By their numbers in this assay, from the lowest: compound 4; then compound 2; then compound 3.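

In this assay, isopropyl in place of 2-hydroxyethyl on a carbonyl carbon gives a number 38 percentage points lower from compound 3 to compound 4 (beyond the scatter), the largest step seen so far among these compounds. Isopropyl in place of 1-methylethenyl gives a number 19 percentage points lower from compound 2 to compound 4 (beyond the scatter), so two side chains without a hydroxy group also stand apart, and the presence or absence of hydroxy does not alone order the three compounds, as the earlier single step might have suggested. With compound 4 lowest of the three, the order now spans all three groups on the carbonyl carbon, but nothing available explains it.

As far as these compounds go, the step from compound 1 to compound 4 cannot be read, so what hydroxy in place of hydrogen does on the saturated chain carbon bound to a carbonyl carbon and two saturated chain carbons remains unknown, and the 1-hydroxy-1-methylethyl group cannot be placed in the order. The compounds shown also leave open how an amine or a longer chain bearing a terminal hydroxy group would stand on the carbonyl carbon.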